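The compounds below may be only part of what the source reports. "The series", "measured", "known", "first", "only" and "open" are said of these compounds alone.

Measured in an ADME assay on MT4 cells (Homo sapiens) for cytotoxicity, read by MTT assay, with a stated time of 5 days; a higher number here means that more compound is tolerated, a lower number that less compound is tolerated:
compound 1 `Cc1cc(C)cc(S(=O)(=O)c2c(C(N)=O)[nH]c3ccc(Cl)cc23)c1`: 13000 nM
compound 2 `Cc1cc(C)cc(S(=O)(=O)c2c(C(=O)N[C@@H]3CCN(Cc4cccnc4)C3)[nH]c3ccc(Cl)cc23)c1`: 36500 nM
compound 3 `Cc1cc(C)cc(S(=O)(=O)c2c(C(=O)N[C@H]3CCN(CC(N)=O)C3)[nH]c3ccc(Cl)cc23)c1`: 28100 nM

Two steps fix the standing of compound 3: a 1.3-fold lower number from compound 2 to compound 3 (0.11 log units; within the scatter) and a 2.2-fold higher number from compound 1 to compound 3 (0.33 log units; beyond the scatter). It therefore belongs to the upper pair of this small set. Compound 4 `Cc1cc(C)cc(S(=O)(=O)c2c(C(=O)NC3CN(CC(N)=O)C3)[nH]c3ccc(Cl)cc23)c1` carries one change from compound 3: 1-(carbamoylmethyl)azetidin-3-yl in place of 1-(carbamoylmethyl)pyrrolidin-3-yl on an amide-type nitrogen and the rest of the structure stays the same. Among the compounds with values here, no measured step alters ring size alone. The closest evidence is that adding a substituted ring on the amide-type nitrogen gave a 2.8-fold higher number from compound 1 to compound 2 (0.45 log units; beyond the scatter) and a 2.2-fold higher number from compound 1 to compound 3 (0.33 log units; beyond the scatter), while exchanging one such substituent for another gave only a 1.3-fold lower number from compound 2 to compound 3 (0.11 log units; within the scatter) as its size. A step beyond the scatter is thus not expected in this assay in either direction. The expected step is a 1.0-fold lower number from compound 3 to compound 4 (0.02 log units; within the scatter) by this estimate. For compound 4 the estimated value is 27000 nM with an expected range from 14000 nM to 50000 nM around it.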

Compound 4, half-maximal cytotoxic concentration: 25500 nM
Compound 4: the middle estimate sits 1.1-fold (0.02 log units) above what was measured; low and high end bracket the measured number.
By their numbers in this assay, from the lowest: compounds 1, 4, 3 and 2 (each within the scatter of the next, the first and the last beyond it).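

In this assay the exchange of 1-(carbamoylmethyl)pyrrolidin-3-yl for 1-(carbamoylmethyl)azetidin-3-yl gives a 1.1-fold lower number from compound 3 to compound 4 (0.04 log units; within the scatter) and so shows a change of ring size alone staying within the scatter. Exchanging 1-((pyridin-3-yl)methyl)pyrrolidin-3-yl for the same azetidine group gives a 1.4-fold lower number from compound 2 to compound 4 (0.16 log units; within the scatter) and also stays within it. In place of hydrogen the group gives a 2.0-fold higher number from compound 1 to compound 4 (0.29 log units; within the scatter) and this step, unlike those from compound 1 to compound 2 and to compound 3, lies within the scatter. As far as these compounds go, whether a piperidin-3-yl ring or a carboxylic acid in place of the carbamoyl group would shift the number stays open. Nothing measured here gives a reason for these numbers.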